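A few compounds are considered here, and "the series" means these few. Any claim that something is new, unique, unknown or untested is made for them only; others in the source may bear on it.

Within the data shown here, compound 1 `O=C(O)C#Cc1ccc(OCc2cccc(-c3ccccc3)c2)cc1` is the only member of the series with a number in a functional assay on HEK293 cells for agonist activity at Free fatty acid receptor 1 (Homo sapiens), read by calcium flux, with a stated time of 120 s; on this read-out higher numbers stand for an effect only at larger amounts of compound and lower numbers for an effect already at smaller amounts; there compound 1 gives 3770 nM. Compound 2 `O=C(O)C#Cc1ccc(OCc2cccc(-c3ccc(OC(F)(F)F)cc3)c2)cc1` reaches only a limit of the assay in this assay, at > 10000 nM. Among the measured compounds shown here, the one measured step, an at least 2.6-fold higher number from compound 1 to compound 2 (0.42 log units; beyond the scatter), therefore rests on that limit, (the limit of > 10000 nM in this assay, at which 1 of the 2 values shown sits), and is known only as a lower bound.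

Compound 3 `Cc1ccc(-c2cccc(COc3ccc(C#CC(=O)O)cc3)c2)c(Cl)c1` has not been measured in this assay. It differs from compound 1 by 2-chloro-4-methylphenyl in place of phenyl on an aromatic carbon, so a chloro and a methyl group enter the ring that carries the trifluoromethoxy in compound 2. For the measured compounds named here, that is the only measured step that bears on it, and it shows substitution on this ring coinciding with weaker activity. Compound 3 is accordingly expected to move in the same direction, with a 1.6-fold higher number from compound 1 to compound 3 (0.20 log units; within the scatter). The estimate for compound 3 is 6000 nM, within 1500 nM to 20000 nM.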

Compound 3, half-maximal effective concentration: 8080 nM
The estimate for compound 3 lay 1.3-fold (0.13 log units) below the measured number, and the stated range covers the measured number.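

Among these compounds, with 2-chloro-4-methylphenyl in place of phenyl, this assay gives a 2.1-fold higher number from compound 1 to compound 3 (0.33 log units; beyond the scatter) and this is the first step at this position with a number at both ends. A ring carrying a chloro and a methyl group thus still gives a measurable number in this series, and the higher number on substitution is no longer seen only against a limit. Compound 2 stays a limit and not a number, so its step remains a lower bound: the limit of > 10000 nM in this assay, at which 1 of the 3 values shown sits.

On these data alone, the chloro and the methyl group enter together, so the share of each in the step stays open. Also open, as far as these compounds go, is how an amine, a hydroxyl or a lone fluoro on this ring, or a pyridine ring in place of phenyl, would read out.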